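The source may report more compounds than this note shows. Statements on the series, on what has been measured and on what is new or still open speak of the compounds shown alone.

Measured so far:
- compound 1, `CCCSc1nc(Cl)c2c(n1)N(Cc1ccccc1)C(C(=O)NCCC1=CCc3ccccc31)N2` — 48800 nM
- compound 2, `CCCSc1nc(Cl)c2c(n1)N(Cc1ccccc1)C(C(=O)N1CCN(C)CC1)N2` — 2800 nM

Both compounds were run in a functional assay on A549 cells (Homo sapiens) for antiproliferative activity, read by MTT assay, with a stated time of 72 h; a lower number here means a stronger inhibitor, a higher number a weaker inhibitor. On these two numbers compound 2 stands lowest; its nearest neighbour is compound 1, whose number is higher by a margin beyond the scatter. Nothing more can be said of that pair, since the two compounds differ in more than one place.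

Compound 3, `CCCSc1nc(Cl)c2c(n1)N(Cc1ccccc1)C(C(=O)NCC(C)C)N2`, is the next point and has not yet been measured in this assay. It keeps the core of compound 2 and differs only at the amide: isobutylamino in place of 4-methylpiperazin-1-yl on a carbonyl carbon. Among the measured compounds shown here, no step between measured compounds matches this change, so its size has to be judged from the two numbers in hand. Compound 1 also carries an open-chain amide substituent on the same carbonyl carbon and gives 48800 nM, which points toward a weaker number for compound 3 than for compound 2.

Compound 3 is therefore expected to lose potency in this assay, with a step of a 5.4-fold higher number from compound 2 to compound 3 (0.73 log units; beyond the scatter). The estimate for compound 3 is 15000 nM, within a range from 4000 nM to 60000 nM.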

Compound 3, half-maximal inhibitory concentration: 48200 nM
The estimate for compound 3 lay 3.2-fold (0.51 log units) below the measured number; low and high end bracket the measured number.
By their numbers in this assay, from the lowest: compound 2; then compounds 3 and 1 (each within the scatter of the next).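

In this assay the amide on this carbonyl carbon now has a direct reading: isobutylamino in place of 4-methylpiperazin-1-yl gives a 17-fold higher number from compound 2 to compound 3 (1.24 log units; beyond the scatter) and marks this position as sensitive to the group it carries. On the saturated chain carbon bound to an amide-type nitrogen, a group of 3 heavy atoms in place of the group of 10 heavy atoms with its two rings gives a 1.0-fold lower number from compound 1 to compound 3 (0.01 log units; within the scatter) and so leaves the number unmoved in this pair, which places compound 1 and compound 3 together, apart from compound 2. Nothing measured on these compounds accounts for either step.

Still open, as far as these compounds go, is which part of the 4-methylpiperazin-1-yl group carries the difference, since the ring, its second nitrogen, its methyl group and the missing amide hydrogen all change together in the step to isobutylamino. A morpholine or piperidine amide, an unsubstituted piperazine amide, or an open-chain dimethylaminoethyl amide would begin to separate these features on the shared core.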